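The compounds below may be only part of what the source reports. "The series", "measured", "known", "first", "only" and "open" are said of these compounds alone.

Compound 1, with the structure `N[C@H]1CC[C@H](Nc2c(C(=O)NCc3cccc(C(F)(F)F)c3)nc(Br)c3cccnc23)CC1`, was tested in a functional assay on HCT-116 cells (Homo sapiens) for cytotoxicity, read by MTT assay, with a stated time of 72 h (a lower number here means a stronger inhibitor, a higher number a weaker inhibitor), but no single number came out of it: for compound 1 the result is "not determined" (no result reported). Compound 2, `O=C(NCc1ccc(F)cc1)c1nc(NCCO)c2cccnc2c1O`, is in the same position, with "not determined" (no result reported) in this assay. For the measured compounds named here, the only compound with a number is compound 3, `CS(=O)(=O)NCCCCCCN(c1nc(C(=O)NCc2ccc(F)cc2)c(O)c2ncccc12)S(C)(=O)=O`, which in this assay gives 3000 nM. Compound 3 shares the core with the others but carries different groups, so it fixes only the rough range in which this series sits.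

Compound 4, `N[C@H]1CC[C@H](Nc2c(C(=O)NC3CCCCC3)nc(Br)c3cccnc23)CC1`, differs from compound 1 at the amide nitrogen: cyclohexyl in place of 3-(trifluoromethyl)benzyl on an amide-type nitrogen. With no number for compound 1 there is nothing to measure this change against, so no direction can be claimed; a step no larger than the usual scatter would be as likely as one in either direction. Compound 4 is therefore expected to land near the range set by compound 3, with an estimated value of 4000 nM and a likely range from 500 nM to 40000 nM.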

Compound 4, half-maximal inhibitory concentration: > 10000 nM
Compound 4: a limit, no number; the forecaster's own chance of this, stated with the estimate: 30%; middle value at least 2.5-fold (0.39 log units) from the limit.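

Compound 4 gives > 10000 nM, which is a limit and not a number. For the compounds shown here, compound 1 has no single number, so no step between compound 1 and compound 4 can be read. On these data alone, whether cyclohexyl or 3-(trifluoromethyl)benzyl on the amide-type nitrogen gives the stronger inhibitor stays open.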